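Flipping One Ring Stereocentre Where Nothing Yet Shows Activity

The source may hold more compounds than are shown below. What is called first, only, known or untested is meant among the compounds shown, and "the series" means these compounds.

Four close relatives of one shared core are compared in a functional assay on CCRF-CEM cells (Homo sapiens) for antiproliferative activity, with a stated time of 72 h; on this read-out higher numbers stand for an effect only at larger amounts of compound and lower numbers for an effect already at smaller amounts. Going by the values given here, compound 1 `Cc1cn([C@@H]2O[C@H](CO)[C@@H](CO)[C@H]2O)c(=O)[nH]c1=O` is the first of them. In this assay compound 1 gives > 100 uM, which is a limit of the assay rather than a number. Compound 2 `Cc1cn([C@@H]2O[C@H](CO)[C@@H](CF)[C@H]2O)c(=O)[nH]c1=O` differs from compound 1 by fluoro in place of hydroxy on a saturated chain carbon bound to a saturated ring carbon. In this assay compound 2 gives > 100 uM, again a limit. The step that the two limits leave unreadable from compound 1 to compound 2 therefore cannot be read. Compound 3 `Cc1cn([C@@H]2O[C@H](CO)[C@@H](CN=[N+]=[N-])[C@@H]2O)c(=O)[nH]c1=O` likewise reaches no number: in this assay compound 3 gives > 100 uM, a limit. All three measured compounds thus sit at the limit of > 100 uM in this assay, at which 3 of the 3 values shown sit, and nothing separates them on this read-out.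

Compound 4 `Cc1cn([C@@H]2O[C@H](CO)[C@@H](CN=[N+]=[N-])[C@H]2O)c(=O)[nH]c1=O` has the same atoms and bonds as compound 3 and differs only in configuration: the two compounds have the same atoms and bonds; at least one stereo element is drawn with a configuration in one of them and without one in the other: 1 of 5 stereo elements differ; a stereocentre at a saturated ring carbon is drawn S in compound 3 and R in compound 4. Among the compounds with values here, no measured step bears on a change of this kind, and the single measured step is itself unreadable. With every measured compound at a limit, there is no number from which a change could be expected to move up or down beyond the scatter. The step that the limit leaves unreadable from compound 3 to compound 4 is therefore expected to be flat, with compound 4 most likely again returning only a limit. For compound 4 the expected value is 150 uM, with a range from 40 uM to 600 uM.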

Compound 4, concentration for half-maximal effect: > 100 uM
Compound 4 gave a limit, no number; the forecaster's own chance of this, stated with the estimate: 85%; the middle value does not contradict the limit.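

In this assay compound 4 gives > 100 uM, which is a limit and not a number. The steps to compound 4 from compound 1, compound 2 and compound 3 therefore cannot be read, and that includes the flipped ring stereocentre: the limit of > 100 uM in this assay, at which 4 of the 4 values shown sit.

From the compounds shown here alone, whether any of these changes to the shared core alters antiproliferative activity at all remains open.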